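A few compounds are considered here, and "the series" means these few. Any claim that something is new, unique, unknown or untested is made for them only; others in the source may bear on it.

Compound 1, `CCC(C)OC(=O)/C=C(C)/C=C/CC(C)CCCC(C)C`, stands highest of the three compounds measured in a physicochemical assay for lipophilicity (a higher number here means a more lipophilic compound, a lower number a more polar compound), where compound 1 gives 7.69. Compound 2, `CCC(C)OC(=O)/C=C(C)/C=C/CC(C)CCCC(C)(C)OC`, gives 6.49 in this assay, and compound 3, `C=CC(C)OC(=O)/C=C(C)/C=C/CC(C)CCCC(C)(C)OC`, gives 5.94. The step of a number 1.20 log units lower from compound 1 to compound 2 (beyond the scatter) is large, and the step of a number 0.55 log units lower from compound 2 to compound 3 (beyond the scatter) is modest; both run downward.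

The unmeasured compound 4, `CC(/C=C/CC(C)CCCC(C)C)=C\C(=O)NC(C)C`, differs from compound 1 in one place: isopropylamino in place of sec-butoxy on a carbonyl carbon. Neither measured step covers an ester turned into an amide, so the two steps only show the scale of movement seen so far in this series. Because the step of a number 1.20 log units lower from compound 1 to compound 2 (beyond the scatter) alone was already large on putting methoxy in place of hydrogen, a change that swaps one hydrogen-bond acceptor for one hydrogen-bond donor and removes one carbon is expected to move compound 4 downward by at least as much. Compound 4 is therefore estimated at 5.6 in this assay, within a range from 4.8 to 6.4, an expected step of a number 2.09 log units lower from compound 1 to compound 4 (beyond the scatter).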

Compound 4, partition coefficient: 5.65
Compound 4: the middle estimate sits 0.05 log units below what was measured; the range from low to high includes it.
By their numbers in this assay, from the lowest: compounds 4 and 3 (each within the scatter of the next); then compound 2; then compound 1.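

Putting isopropylamino in place of sec-butoxy on a carbonyl carbon gives a number 2.04 log units lower from compound 1 to compound 4 (beyond the scatter) in this assay, so exchanging the whole group at this carbonyl carbon can shift the number by a large step. The earlier change in this group altered only part of it, vinyl in place of ethyl, and gave the modest a number 0.55 log units lower from compound 2 to compound 3 (beyond the scatter). No measurement shown here explains the size of the new step.

This single change replaces the oxygen with a nitrogen, adds a hydrogen-bond donor and shortens the group, so the share of each stays unresolved; sec-butylamino or isopropoxy on the same carbonyl carbon would begin to separate them. Also open, from the compounds shown here alone, is whether isopropylamino would give a step of similar size on compound 2, which carries the methoxy group.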